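A few compounds are considered here, and "the series" means these few. Any claim that something is new, unique, unknown or untested is made for them only; others in the source may bear on it.

In a physicochemical assay for solubility, read by nephelometry, in phosphate buffer, at pH 7.4 (a lower number here means a less soluble compound, a higher number a more soluble compound), compound 1 (`Cc1sc(-c2ccccc2C(N)=O)cc1C(=O)Nc1nc2c(s1)CCC2`) gives 1950 nM and compound 2 (`Cc1sc(-c2ccccc2C(=O)NCCO)cc1C(=O)Nc1nc2c(s1)CCC2`) gives 980 nM. These two values lie within the usual scatter of each other, so compound 2 does not stand apart from compound 1. Compound 3 (`Cc1sc(-c2ccccc2C(=O)NCCC(N)=O)cc1C(=O)Nc1nc2c(s1)CCC2`) differs from compound 2 at the end of its side chain: carbamoyl in place of hydroxy on a saturated chain carbon, two bonds along the chain from an amide-type nitrogen. Put simply, 2-hydroxyethyl becomes 2-carbamoylethyl. Within the data shown here, the one measured step that bears on this, made at the same amide-type nitrogen, is a 2.0-fold lower number from compound 1 to compound 2 (0.30 log units; within the scatter). Among the measured compounds shown here, no measurement yet tests a carbamoyl group on this chain. For the measured compounds named here, with that single step as the only guide, no change beyond the scatter is expected in this assay, in either direction. The estimated step is a 1.0-fold higher number from compound 2 to compound 3 (0.01 log units; within the scatter). For compound 3 the expected solubility is 1000 nM, with an estimated range of 400 nM to 2500 nM.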

Compound 3, solubility: 3910 nM
Compound 3: middle estimate off by 3.9-fold (0.59 log units), on the low side; the measured number lies above the stated range.
By their numbers in this assay, from the lowest: compounds 2, 1 and 3 (each within the scatter of the next, the first and the last beyond it).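

In this assay the end of this side chain proves to matter, with a 4.0-fold higher number from compound 2 to compound 3 (0.60 log units; beyond the scatter) for carbamoyl in place of hydroxy on a saturated chain carbon, two bonds along the chain from an amide-type nitrogen. Set against hydrogen on that nitrogen, 2-carbamoylethyl gives a 2.0-fold higher number from compound 1 to compound 3 (0.30 log units; within the scatter) and so does not stand apart from the simple primary amide. No evidence here accounts for the difference between the hydroxy and carbamoyl chain ends.

The compounds shown leave open whether this step is particular to carbamoyl or would also appear with another chain end, such as an amine or a carboxylic acid. They also leave open how a longer chain carrying the same carbamoyl would compare.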